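The source may report more compounds than this note shows. Statements on the series, on what has been measured and on what is new or still open speak of the compounds shown alone.

Within the data shown here, compound 1 `COc1cc(/C(Cl)=C/C=C(\C#N)C(=O)c2c[nH]c3ccc(Br)cc23)cc(OC)c1OC` is the weaker-tolerated of the two compounds measured so far in an ADME assay on Vero cells (Chlorocebus sabaeus) for cytotoxicity, read by sulforhodamine B assay, with a stated time of 48 h (a lower number here means that less compound is tolerated, a higher number that more compound is tolerated), where compound 1 gives 41500 nM. Among the measured compounds shown here, its one measured neighbour, compound 2 `COc1ccc(/C(Cl)=C/C=C(\C#N)C(=O)c2c[nH]c3ccc(Br)cc23)cc1OC`, gives 51800 nM in this assay, and the step of a 1.2-fold higher number from compound 1 to compound 2 (0.10 log units; within the scatter) is the only one recorded. Compound 3 `COc1cc(/C(Cl)=C/C=C(\C#N)C(=O)c2c(C)[nH]c3ccccc23)cc(OC)c1OC` has not yet been measured. It differs from compound 1 by 2-methyl-1H-indol-3-yl in place of 5-bromo-1H-indol-3-yl on a carbonyl carbon. For the measured compounds named here, no measured step touches the group on the carbonyl carbon: the step from compound 1 to compound 2 concerns a methoxy on an aromatic carbon of the other part of the shared core, and that step stayed within the scatter. There is therefore nothing in the measured pairs that points to a change in either direction for the exchange on the carbonyl carbon, and the expectation is that compound 3 stays close to compound 1, with the expected step of a 1.0-fold lower number from compound 1 to compound 3 (0.02 log units; within the scatter) not beyond the scatter. Compound 3 is estimated to give 40000 nM in this assay, expected to fall between 15000 nM and 110000 nM.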

Compound 3, concentration lethal to 50% of the cells: 68300 nM
The estimate for compound 3 lay 1.7-fold (0.23 log units) below the measured number; low and high end bracket the measured number.
By their numbers in this assay, from the lowest: compounds 1, 2 and 3 (each within the scatter of the next).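

In this assay, among these compounds, the exchange on the carbonyl carbon, 2-methyl-1H-indol-3-yl in place of 5-bromo-1H-indol-3-yl, gives a 1.6-fold higher number from compound 1 to compound 3 (0.22 log units; within the scatter) and is the first measured step at this position. It shows that this position can lose the bromine and take a methyl, with the same count of heavy atoms in the group and no net charge on either side, without a step beyond the scatter, just as the step on the other part of the shared core gives a 1.2-fold higher number from compound 1 to compound 2 (0.10 log units; within the scatter) and stays within it. No measurement on hand offers an explanation for the size of the step on the carbonyl carbon.

The single exchange removes the bromine and adds the methyl together, so the compounds shown cannot assign any part of the step to either group, and a bare 1H-indol-3-yl would be needed to separate them. They also leave open whether this position stays as undemanding when the group on the carbonyl carbon carries an amine or a carboxylic acid, or a longer chain in place of the methyl.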